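Hydrazide to sulfanyl-oxadiazole on the coumarin ether side chain

The source may hold more compounds than are shown below. What is called first, only, known or untested is meant among the compounds shown, and "the series" means these compounds.

Two compounds of this series have numbers in an assay for inhibition of Amine oxidase [flavin-containing] A (Bos taurus), read by fluorescence, with a stated time of 30 min; a higher number here means a weaker inhibitor, a lower number a stronger inhibitor. Compound 1 `Cc1cc(=O)oc2cc(OCC(=O)NN)ccc12` gives 0.0112 nM in this assay. Compound 2 `Cc1c(C)c2ccc(OCC(=O)NN)cc2oc1=O` gives 0.00501 nM in this assay. For the measured compounds named here, compound 1 therefore stands highest of the two numbers; the single step of a 2.2-fold lower number from compound 1 to compound 2 (0.35 log units; beyond the scatter) is a methyl in place of hydrogen on an aromatic carbon and lies beyond the scatter, though only modestly.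

Compound 3 `Cc1cc(=O)oc2cc(OCc3nnc(S)o3)ccc12` is not yet measured. It differs from compound 1 by 5-sulfanyl-1,3,4-oxadiazol-2-yl in place of aminocarbamoyl on a saturated chain carbon bound to an oxygen on an aromatic ring. Going by the values given here, this change touches the side chain, not the aromatic carbon altered between compound 1 and compound 2, so no measured step bears on it directly: the only step available concerns a different part of the shared core and gives no guidance on exchanging the aminocarbamoyl group for a five-membered aromatic ring with three hetero atoms. Among the compounds with values here, with no comparable step, the expectation for compound 3 is held loosely, leaning towards a somewhat higher number than compound 1, with wide bounds in both directions.

The expected step in this assay is a 2.7-fold higher number from compound 1 to compound 3 (0.43 log units; beyond the scatter). Compound 3 is thus estimated at 0.03 nM in this assay, within a range from 0.005 nM to 0.2 nM.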

Compound 3, inhibition constant: 0.012 nM
Compound 3: the middle estimate sits 2.5-fold (0.40 log units) above what was measured; low and high end bracket the measured number.
By their numbers in this assay, from the lowest: compound 2; then compounds 1 and 3 (each within the scatter of the next).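

On the saturated chain carbon bound to an oxygen on an aromatic ring, the exchange of aminocarbamoyl for 5-sulfanyl-1,3,4-oxadiazol-2-yl gives a 1.1-fold higher number from compound 1 to compound 3 (0.03 log units; within the scatter) in this assay. At this place on the core of compound 1, the open aminocarbamoyl group is therefore not needed for a number at this level: a larger group with one five-membered aromatic ring and different counts of hydrogen-bond donors and acceptors serves equally well in this assay. What allows the two groups to give matching numbers cannot be told from the data in hand.

Still open, as far as these compounds go, is whether the sulfanyl group on the new ring contributes to this result, which an amine or a methyl group in its place would test, and whether a carboxylic acid or a longer chain would also be accepted on the same side chain. Also open, from the compounds shown here alone, is whether the methyl in place of hydrogen on an aromatic carbon, which gives a 2.2-fold lower number from compound 1 to compound 2 (0.35 log units; beyond the scatter), carries over when 5-sulfanyl-1,3,4-oxadiazol-2-yl is present on the side chain.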